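Methoxy to hydroxy: compound 4 in the series

The compounds below may be only part of what the source reports. "The series", "measured", "known", "first", "only" and "open" are said of these compounds alone.

Going by the values given here, compound 3 `COc1cc(C)cc(-c2nn(CC#N)cc2-c2ccnc(-c3ccc(N(C)C)cc3)c2)c1` gives 567 nM in a functional assay on SNB-19 cells (Homo sapiens) for inhibition, read by sulforhodamine B assay, with a stated time of 48 h (on this read-out lower numbers stand for stronger inhibition of growth and higher numbers for weaker inhibition of growth), the lowest of the three numbers measured so far; compound 2 `Cc1cc(O)cc(-c2nn(CC#N)cc2-c2ccnc(-c3ccc(Oc4ccccc4)cc3)c2)c1` with 1070 nM sits within the scatter of it, while compound 1 `COc1cc(C)cc(-c2nn(CC#N)cc2-c2ccc(-c3cccc(C(C)=O)c3)nc2)c1` with 6620 nM lies beyond the scatter above it. Among the compounds with values here, no two measured compounds differ in only one place, so no single step can be read off directly. Compound 4 `Cc1cc(O)cc(-c2nn(CC#N)cc2-c2ccnc(-c3ccc(N(C)C)cc3)c2)c1` is the next member: hydrogen in place of methyl on an oxygen on an aromatic ring. Compound 2 already carries the hydroxy group, but it differs from compound 3 in more than this one place and so gives no direct reading of the change. The step from compound 3 to compound 4 is expected to be a 1.0-fold lower number from compound 3 to compound 4 (0.01 log units; within the scatter), within the scatter, with no firm direction. Compound 4 is estimated at 550 nM, range 200 nM to 1500 nM.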

Compound 4, concentration for 50% growth inhibition: 4540 nM
For compound 4 the middle estimate is 8.3-fold (0.92 log units) below the measured one; the measured number lies above the stated range.
By their numbers in this assay, from the lowest: compounds 3 and 2 (each within the scatter of the next); then compounds 4 and 1 (each within the scatter of the next).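

In this assay, the change from methoxy to hydroxy on the aromatic ring gives an 8.0-fold higher number from compound 3 to compound 4 (0.90 log units; beyond the scatter) in the series' first reading at this position, so the methyl on that oxygen is not interchangeable with hydrogen here. With the hydroxy group held, dimethylamino in place of phenoxy gives a 4.2-fold higher number from compound 2 to compound 4 (0.63 log units; beyond the scatter) and so moves the number in the same direction. Nothing measured here accounts for either step. As far as these compounds go, whether ethoxy or an amine in place of methoxy keeps the lower number stays open. Also open, from the compounds shown here alone, is whether the methoxy to hydroxy step has the same size with phenoxy in place of dimethylamino.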